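The source may hold more compounds than are shown below. What is called first, only, known or untested is meant among the compounds shown, and "the series" means these compounds.

Measured compounds:
- compound 1, `O=c1cc(-c2ccccc2)oc2cc(OCCCCNc3nc4c(F)cc(F)cc4s3)cc(O)c12`: 36.8 ug/mL
- compound 2, `O=c1cc(-c2ccccc2)oc2cc(OCCCCNc3nc4ccc(C(F)(F)F)cc4s3)cc(O)c12`: 37.2 ug/mL

In a functional assay on SK-OV-3 cells (Homo sapiens) for cytotoxicity, read by sulforhodamine B assay, with a stated time of 48 h (a lower number here means a stronger inhibitor, a higher number a weaker inhibitor), compound 1 gives 36.8 ug/mL, and compound 2 gives 37.2 ug/mL. Compound 2 holds the higher of the two numbers, but its gap to compound 1 lies within the scatter, so the two compounds are not distinguishable on these data. Compound 3, `O=C(O)c1ccc2nc(NCCCCOc3cc(O)c4c(=O)cc(-c5ccccc5)oc4c3)sc2c1`, has not yet been measured in this assay. It differs from compound 2 by carboxy in place of trifluoromethyl on an aromatic carbon. For the measured compounds named here, no measured pair shows this exchange, so the size of the step can only be guessed. A moderate step toward a higher number in this assay is expected, though a result within the scatter of compound 2 would not be surprising. The step expected is a 1.3-fold higher number from compound 2 to compound 3 (0.11 log units; within the scatter). Compound 3 is therefore estimated at 48 ug/mL, with a range from 25 ug/mL to 90 ug/mL.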

Compound 3, half-maximal inhibitory concentration: 43.3 ug/mL
Estimate against measurement, compound 3: 1.1-fold (0.04 log units) above, within the range that was stated.
By their numbers in this assay, from the lowest: compounds 1, 2 and 3 (each within the scatter of the next).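

In this assay, for the compounds shown here, carboxy in place of trifluoromethyl on an aromatic carbon, meta to a fused ring and para to a fused ring, gives the first single-place step, a 1.2-fold higher number from compound 2 to compound 3 (0.07 log units; within the scatter). Carboxy carries a hydrogen-bond donor and acceptor and trifluoromethyl carries neither, yet this exchange does not separate the compounds on these data. The exchange of 6-carboxy-1,3-benzothiazol-2-yl for 4,6-difluoro-1,3-benzothiazol-2-yl on an amine nitrogen gives a 1.2-fold higher number from compound 1 to compound 3 (0.07 log units; within the scatter), so it also does not separate them.

No data at hand bear on the cause of these results. From the compounds shown here alone, it remains open whether an amine or a methyl ester at this position, or a longer chain in place of the present one, would give a step beyond the scatter.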